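Indol-3-yl in place of furan-2-yl: working notes

The source may report more compounds than this note shows. Statements on the series, on what has been measured and on what is new or still open speak of the compounds shown alone.

All compounds share one core and differ at a single place. In a functional assay on MGC-803 cells (Homo sapiens) for cytotoxicity, read by MTT assay, with a stated time of 72 h (a higher number here means a weaker inhibitor, a lower number a stronger inhibitor), compound 1 `O=C1C(=Cc2ccc(Cl)cc2)C(=O)N(c2ccc(Cl)cc2)N1c1ccc(Cl)cc1` gives 32600 nM and compound 2 `COc1cccc(C=C2C(=O)N(c3ccc(Cl)cc3)N(c3ccc(Cl)cc3)C2=O)c1` gives 26600 nM, with a 1.2-fold lower number from compound 1 to compound 2 (0.09 log units; within the scatter). Compound 3 `O=C1C(=Cc2ccco2)C(=O)N(c2ccc(Cl)cc2)N1c1ccc(Cl)cc1` gives 12800 nM, the lowest of the three numbers. Two measured steps lead to it: a 2.5-fold lower number from compound 1 to compound 3 (0.41 log units; beyond the scatter) and a 2.1-fold lower number from compound 2 to compound 3 (0.32 log units; beyond the scatter).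

Next is compound 4 `O=C1C(=Cc2c[nH]c3ccccc23)C(=O)N(c2ccc(Cl)cc2)N1c1ccc(Cl)cc1`, in which 1H-indol-3-yl stands in place of furan-2-yl on a double-bonded chain carbon bound to a double-bonded ring carbon: 1H-indol-3-yl in place of furan-2-yl on a double-bonded chain carbon bound to a double-bonded ring carbon. Among the compounds with values here, all three measured steps concern this same place, but none involves 1H-indol-3-yl, and no measured compound carries a hydrogen-bond donor in this group. The largest of them, a 2.5-fold lower number from compound 1 to compound 3 (0.41 log units; beyond the scatter), is still modest, so a large move is not expected. Compound 3 keeps the lowest number at 12800 nM, and both compounds with a larger group here lie higher, so any move is expected to lean upward. The expected change is a 1.3-fold higher number from compound 3 to compound 4 (0.10 log units; within the scatter), which means no clear step. For compound 4 the estimated value in this assay is 16000 nM, with an expected range of 6000 nM to 40000 nM.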

Compound 4, half-maximal inhibitory concentration: 21800 nM
For compound 4 the middle estimate is 1.4-fold (0.13 log units) below the measured one; low and high end bracket the measured number.
By their numbers in this assay, from the lowest: compounds 3, 4, 2 and 1 (each within the scatter of the next, the first and the last beyond it).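

In this assay, within the data shown here, compound 4 is the first compound with a hydrogen-bond donor in the group on the double-bonded chain carbon, and 1H-indol-3-yl brings a six-membered aromatic ring alongside its five-membered one, yet neither addition produces a step that can be read: a 1.7-fold higher number from compound 3 to compound 4 (0.23 log units; within the scatter). The same holds against the two phenyl-bearing compounds, with a 1.2-fold lower number from compound 2 to compound 4 (0.09 log units; within the scatter) and a 1.5-fold lower number from compound 1 to compound 4 (0.17 log units; within the scatter), so compound 4 cannot be separated from any of the other three, and compound 3, whose steps to compound 1 and compound 2 lie beyond the scatter, no longer stands apart from every other compound. No measurement shown here bears on the reason for this result.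

Since 1H-indol-3-yl differs from furan-2-yl in both ring content and donor, these compounds cannot separate the two, and 1-methylindol-3-yl or pyrrol-2-yl at this place would be needed to do so. From the compounds shown here alone, how an amine or a carboxylic acid on this group would read in this assay also remains open.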